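Expected Vero Cell Tolerability of Compound 3

The source may hold more compounds than are shown below. What is called first, only, known or untested is meant among the compounds shown, and "the series" means these compounds.

Of the compounds shown here, two built on the same core have been tested in an ADME assay on Vero cells (Chlorocebus sabaeus) for cytotoxicity, with a stated time of 7 days; a lower number here means that less compound is tolerated, a higher number that more compound is tolerated. For the measured compounds named here, compound 1 `COc1ccc2[nH]c(C(=O)N3CC(=O)N(Cc4ccccc4)[C@@H](CN4CCC5(CC4)CC5)C3)cc2c1` gives 17100 nM in this assay, the higher of the two numbers so far. Going by the values given here, compound 2 `COc1ccc2[nH]c(C(=O)N3CC(=O)N(Cc4ccc[nH]4)[C@@H](Cc4ccccc4)C3)cc2c1` gives 15200 nM in this assay, a number that sits within the usual scatter of the one for compound 1, so the two cannot be told apart. Compound 3 `COc1ccc2[nH]c(C(=O)N3CC(=O)N(Cc4ccccc4)[C@@H](CN4C(=O)c5ccccc5C4=O)C3)cc2c1` has not yet been measured. It differs from compound 1 by a group of 11 heavy atoms (8 carbon, 1 nitrogen, 2 oxygen; one five-membered non-aromatic ring with 1 hetero atom, one six-membered aromatic ring of carbon only) in place of a group of 8 heavy atoms (7 carbon, 1 nitrogen; one three-membered non-aromatic ring of carbon only, one six-membered non-aromatic ring with 1 hetero atom), on a saturated chain carbon bound to a saturated ring carbon; everything else is kept as in compound 1. Among the compounds with values here, no measured pair shows this kind of exchange, so there is no step to lean on. Since the two numbers seen so far lie close together, only a small shift is expected, about the size of a 1.1-fold higher number from compound 1 to compound 3 (0.02 log units; within the scatter), which means none beyond the scatter. Compound 3 is therefore estimated at 18000 nM, within a range from 8000 nM to 40000 nM.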

Compound 3, half-maximal cytotoxic concentration: 41000 nM
Estimate against measurement, compound 3: 2.3-fold (0.36 log units) below; the measured number lies above the stated range.
By their numbers in this assay, from the lowest: compounds 2 and 1 (each within the scatter of the next); then compound 3.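

In this assay, the exchange on a saturated chain carbon bound to a saturated ring carbon gives a 2.4-fold higher number from compound 1 to compound 3 (0.38 log units; beyond the scatter), so this place can move the number beyond the scatter, something the two close earlier values did not reveal. This single step swaps one whole group for another: the three-membered and six-membered non-aromatic rings leave, while a five-membered non-aromatic ring, a six-membered aromatic ring and two double bonds outside aromatic rings enter, so no one feature can be singled out. Nothing measured alongside this result bears on why the number moved.

From the compounds shown here alone, it remains open whether a simple dimethylamine or an open-chain amide at this place would give a similar number. Going by these compounds, it is also open whether the same exchange would give a similar step if other parts of compound 1 were changed.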